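Cytotoxicity of Compound 4 Expected to Stay at the Limit

The source may hold more compounds than are shown below. What is called first, only, known or untested is meant among the compounds shown, and "the series" means these compounds.

The study compares three measured compounds and one not yet measured in an ADME assay on NCM460 cells (Homo sapiens) for cytotoxicity, read by MTT assay, with a stated time of 72 h; a higher number here means a weaker inhibitor, a lower number a stronger inhibitor. Among the compounds with values here, compound 1 `COc1ccc(NC(=O)c2cccc(/C=C3\CC(=O)N(c4ccccc4)C3=O)c2)cc1` is the first of them. In this assay compound 1 gives > 100000 nM, which is a limit of the assay rather than a number. Compound 2 `COc1ccc(NC(=O)c2cccc(/C=C3\CC(=O)N(c4ccc(C)cc4)C3=O)c2)cc1` differs from it by methyl in place of hydrogen on an aromatic carbon. In this assay compound 2 gives > 100000 nM, again a limit. The step that the two limits leave unreadable from compound 1 to compound 2 therefore cannot be sized. Compound 3 `CCCCCN1C(=O)C/C(=C\c2cccc(C(=O)NCCCC)c2)C1=O` carries alkyl chains where the first two carry aromatic groups. In this assay compound 3 gives > 100000 nM, which is a limit as well. Compound 3 thus stands where every value shown stands: the limit of > 100000 nM in this assay, at which 3 of the 3 values shown sit.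

Compound 4 `CCCCCN1C(=O)C/C(=C\c2cccc(C(=O)Nc3ccc(OC)cc3)c2)C1=O` differs from compound 3 by 4-methoxyphenyl in place of butyl on an amide-type nitrogen. Within the data shown here, no measured step bears on this change; the only measured step is unreadable and concerns a different change. An expected step of no size beyond the scatter is given as a step that the limit leaves unreadable from compound 3 to compound 4, because the limit of > 100000 nM in this assay, at which 3 of the 3 values shown sit, holds for every value shown. Compound 4 is therefore expected to give 150000 nM in this assay, with a range from 100000 nM to 400000 nM, most likely reported as a limit once more.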

Compound 4, half-maximal inhibitory concentration: > 100000 nM
Compound 4 ended at the assay's limit (the forecaster's own chance of this, stated with the estimate: 90%); the middle value lies beyond the limit too.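

No new step can be read from compound 4: its steps from compound 1, compound 2 and compound 3 all join limits of the assay, so none of them can be sized. All four compounds stand at the same place: the limit of > 100000 nM in this assay, at which 4 of the 4 values shown sit. The compounds shown leave open at what concentration in this assay any of them would reach half-maximal inhibition.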